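From carbamoyl to sulfamoylmethyl on the side chain

The source may hold more compounds than are shown below. What is called first, only, known or untested is meant among the compounds shown, and "the series" means these compounds.

Measured in a functional assay on the whole organism with Rattus norvegicus as the target (a higher number here means that more compound is needed for the effect, a lower number that less compound is needed), so far:
Compound 1 `N=c1sc2cc(OC(F)(F)F)ccc2n1Cc1ccccc1` gives > 10 mg/kg as a limit.
Compound 2 `COC(=O)Cn1c(=N)sc2cc(OC(F)(F)F)ccc21` gives > 10 mg/kg as a limit.
Compound 3 `N=c1sc2cc(OC(F)(F)F)ccc2n1CC(N)=O` gives 7 mg/kg as a number.

Within the data shown here, compound 3 (7 mg/kg) holds the only number of the three. The other two values are limits. Compound 4 `N=c1sc2cc(OC(F)(F)F)ccc2n1CCS(N)(=O)=O` differs from it by sulfamoylmethyl in place of carbamoyl on a saturated chain carbon bound to an aromatic nitrogen in the side chain, with sulfamoylmethyl in place of carbamoyl on a saturated chain carbon bound to an aromatic nitrogen. Among the measured compounds shown here, two measured steps bear on this side chain, an at least 1.4-fold lower number from compound 1 to compound 3 (0.15 log units; that floor lies within the scatter) and an at least 1.4-fold lower number from compound 2 to compound 3 (0.15 log units; that floor lies within the scatter) in size, and both floors lie within the scatter. The step that the two limits leave unreadable from compound 1 to compound 2 adds nothing readable. In this assay no change beyond the scatter is therefore expected, and the expected step is a 1.1-fold higher number from compound 3 to compound 4 (0.06 log units; within the scatter) in size. The estimate for compound 4 is 8 mg/kg with 3 mg/kg to 20 mg/kg as its expected range.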

Compound 4, dose for half-maximal effect: 6 mg/kg
Beside the measured number, compound 4's estimate is 1.3-fold (0.12 log units) above it; low and high end bracket the measured number.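

In this assay the step is a 1.2-fold lower number from compound 3 to compound 4 (0.07 log units; within the scatter), so 2-sulfamoylethyl and carbamoylmethyl stand level on the saturated chain carbon bound to an aromatic nitrogen, and this place now carries two numbers instead of one. Against the other two groups the steps read an at least 1.6-fold lower number from compound 2 to compound 4 (0.22 log units; that floor lies within the scatter) and an at least 1.6-fold lower number from compound 1 to compound 4 (0.22 log units; that floor lies within the scatter), and neither floor goes beyond the scatter. They stay floors because compound 1 and compound 2 each stand at a limit: the limit of > 10 mg/kg in this assay, at which 2 of the 4 values shown sit.

From the compounds shown here alone, how a carboxylic acid or an amine would fare at this place remains open. Going by these compounds, how far compound 1 and compound 2 actually lie from compound 4 also stays unknown.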